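Triazene half-lives: bromo in place of acetyl

The source may hold more compounds than are shown below. What is called first, only, known or untested is meant among the compounds shown, and "the series" means these compounds.

Measured so far:
compound 1 `CN(/N=N/c1ccc(C#N)cc1)C(=O)CCc1ccc(O)cc1`: 86.4 h
compound 2 `CC(=O)c1ccc(/N=N/N(C)C(=O)NCCSc2ccc(O)cc2)cc1`: a limit, > 240 h
compound 3 `CN(/N=N/c1ccc(Br)cc1)C(=O)CCc1ccc(O)cc1`: 106 h

In a physicochemical assay for pharmacokinetics, read by HPLC, in phosphate buffer, at pH 7.4 (a higher number here means that the compound lasts longer, a lower number that the compound disappears faster), compound 1 gives 86.4 h and compound 3 gives 106 h. Going by the values given here, the one step measured so far, a 1.2-fold higher number from compound 1 to compound 3 (0.09 log units; within the scatter), does not rise out of the scatter. Compound 2 stands apart from both: in this assay compound 2 returns only a limit, > 240 h, so that the limit of > 240 h in this assay, at which 1 of the 3 values shown sits, is the whole of what is known about it; no number can be set against compounds 1 and 3.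

Compound 4 `CN(/N=N/c1ccc(Br)cc1)C(=O)NCCSc1ccc(O)cc1` has not yet been measured. It differs from compound 2 by bromo in place of acetyl on an aromatic carbon. Among the compounds with values here, the only measured step that bears on this change is the bromo-for-cyano exchange on the same position in the pair of compounds 1 and 3, which stayed within the scatter; an acetyl-for-bromo exchange itself has not been measured, and nothing among the three compounds ties either group to a shift in this assay. On that basis no step beyond the scatter is expected from compound 2 to compound 4 in this assay, and since compound 2 sits at the limit, compound 4 is expected to sit near or at that limit as well: compound 4 is estimated at 280 h, from 120 h to 650 h. The step this implies, a step that the limit leaves unreadable from compound 2 to compound 4, is expected to be nil within the scatter.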

Compound 4, half-life: > 240 h
Compound 4: no number, only a limit; the forecaster's own chance of this, stated with the estimate: 60%; the middle value does not contradict the limit.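

In this assay compound 2 and compound 4 both return only limits, so no step between them can be read, and the size of the change to bromo in place of acetyl stays unknown: the limit of > 240 h in this assay, at which 2 of the 4 values shown sit.

The compounds shown leave open what the half-lives of compound 2 and compound 4 actually are, and whether the two differ at all.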